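A few compounds are considered here, and "the series" means these few. Any claim that something is new, unique, unknown or untested is made for them only; others in the source may bear on it.

Compound 1 `COc1ccccc1/C=C/C(=O)OC/C=C/c1cc(OC)c(OC)cc1OC` and compound 2 `COc1cc(OC)c(OC)cc1/C=C/COC(=O)/C=C/c1ccccc1Cl` share one core and differ in one place. In a functional assay on the whole organism (strain Kunming) with Mus musculus as the target, with a stated time of 0.5 h, at a dose of 300 mg/kg by the intraperitoneal route (a higher number here means a weaker effect of the compound at the dose given, a lower number a stronger effect), compound 1 gives 100%. In this assay compound 2 gives 50%, the lowest of the two numbers shown, and the step of a number 50 percentage points lower from compound 1 to compound 2 (beyond the scatter) goes with chloro in place of methoxy on an aromatic carbon. Compound 3 `COc1cc(OC)c(OC)cc1/C=C/COC(=O)/C=C/c1ccc(F)cc1` has not yet been measured. It differs from compound 2 by 4-fluorophenyl in place of 2-chlorophenyl on a double-bonded chain carbon bound to a double-bonded chain carbon. The single measured step concerns an exchange at another place on the molecule, so it gives no direct guide to this change, and no step of the present kind is among the numbers shown. The expectation for compound 3 therefore rests on the value of compound 2 alone, with a wide range on either side. Compound 3 is estimated at 60%, between 30% and 100%. That estimate means an expected step of a number 10 percentage points higher from compound 2 to compound 3 (within the scatter), which is not beyond the scatter.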

Compound 3, a percentage reported as activity, at one dose (the size of the read-out at that dose, not a potency): 75%
Compound 3: the middle estimate sits 15 percentage points below what was measured, within the range that was stated.
By their numbers in this assay, from the lowest: compound 2; then compound 3; then compound 1.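

In this assay, the ring on this double-bonded chain carbon clearly affects the read-out: 4-fluorophenyl in place of 2-chlorophenyl goes with a number 25 percentage points higher from compound 2 to compound 3 (beyond the scatter), so the two halogen-bearing rings are not interchangeable. Set against 2-methoxyphenyl, 4-fluorophenyl goes with a number 25 percentage points lower from compound 1 to compound 3 (beyond the scatter), which puts this group in the middle of the three rings tried here, with a stronger effect than 2-methoxyphenyl and a weaker one than 2-chlorophenyl. Nothing available explains why these rings differ.

Both the halogen and its place on the ring change together, so the compounds shown cannot tell which of the two goes with the step. Also open, as far as these compounds go, is how a ring carrying an amine or a carboxylic acid would read in this assay.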